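From Isopropyl to Cyano: Expecting a Weaker Inhibitor

The source may report more compounds than this note shows. Statements on the series, on what has been measured and on what is new or still open speak of the compounds shown alone.

Three compounds share one core and differ only in the group on an aromatic carbon of a six-membered aromatic ring with 2 nitrogen. Compound 1 `Fc1cc2nc(-c3cncnc3)n(C3CC3)c2cc1F` carries hydrogen there and gives 22 nM in an assay on cells for inhibition of cytochrome P450 11B2, mitochondrial (Homo sapiens), read by HPLC, with a stated time of 90 min; a lower number here means a stronger inhibitor, a higher number a weaker inhibitor. Compound 2 `Cc1ncncc1-c1nc2cc(F)c(F)cc2n1C1CC1` carries methyl and gives 17 nM in this assay. Compound 3 `CC(C)c1ncncc1-c1nc2cc(F)c(F)cc2n1C1CC1` carries isopropyl and gives 5 nM in this assay, the lowest of the three numbers; the steps of a 4.4-fold lower number from compound 1 to compound 3 (0.64 log units; beyond the scatter) and a 3.4-fold lower number from compound 2 to compound 3 (0.53 log units; beyond the scatter) both lie beyond the scatter, whereas a 1.3-fold lower number from compound 1 to compound 2 (0.11 log units; within the scatter) does not.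

Compound 4 `N#Cc1ncncc1-c1nc2cc(F)c(F)cc2n1C1CC1` arises from compound 3 by the change (cyano in place of isopropyl on an aromatic carbon). For the measured compounds named here, no measured compound carries cyano, so the expectation rests on these three steps alone: isopropyl gave the lowest number, while hydrogen and methyl, each with fewer heavy atoms, gave higher numbers, and cyano is closer to those in heavy-atom count. The expected step is a 3.0-fold higher number from compound 3 to compound 4 (0.48 log units; beyond the scatter). Compound 4 is therefore estimated at 15 nM in this assay, with a likely range from 5 nM to 45 nM.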

Compound 4, half-maximal inhibitory concentration: 13 nM
Beside the measured number, compound 4's estimate is 1.2-fold (0.06 log units) above it; low and high end bracket the measured number.
By their numbers in this assay, from the lowest: compound 3; then compounds 4, 2 and 1 (each within the scatter of the next).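

Replacing isopropyl with cyano in this assay gives a 2.6-fold higher number from compound 3 to compound 4 (0.41 log units; beyond the scatter), so the lower number seen with isopropyl does not carry over to this group on the aromatic carbon next to the ring nitrogen. Cyano cannot be separated from methyl, with a 1.3-fold lower number from compound 2 to compound 4 (0.12 log units; within the scatter), or from hydrogen, with a 1.7-fold lower number from compound 1 to compound 4 (0.23 log units; within the scatter), which leaves isopropyl as the only one of these four groups that stands apart from the others at this position. Nothing shown here explains the difference between isopropyl and cyano, or says what the added hydrogen-bond acceptor of cyano contributes.

Going by these compounds, whether a tert-butyl group or a longer chain such as n-propyl would match or go below compound 3 remains open. How an amine or a methoxy group would behave at this position is equally unknown.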